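Swapping phenyl for a triazole on a shared core

The compounds below may be only part of what the source reports. "The series", "measured", "known", "first", "only" and "open" are said of these compounds alone.

Measured compounds:
- compound 1 `Cc1c2c(nn1-c1nnc(-c3ccc(OC(C)C)c(C#N)c3)s1)CCN(CCC(=O)O)C2`: 2.76
- compound 2 `CC(C)Oc1ccc(-c2nnc(-c3ccccc3)s2)cc1Cl`: 8.65
- compound 3 `Cc1nc(C)c(-c2nnc(-c3ccc(OC(C)C)c(Cl)c3)s2)s1`: 7.76

In a physicochemical assay for lipophilicity, at pH 7.4 (a lower number here means a more polar compound, a higher number a more lipophilic compound), compound 2 gives 8.65, the highest of the three numbers. Its nearest neighbour is compound 3, which gives 7.76; compound 1, at 2.76, lies far away from both.

Compound 4 `CC(C)Oc1ccc(-c2nnc(-n3cncn3)s2)cc1Cl` has not yet been measured. It differs from compound 2 in one place: 1H-1,2,4-triazol-1-yl in place of phenyl on an aromatic carbon. For the measured compounds named here, the only measured step that bears on this position is the one from compound 2 to compound 3, where a different group took the place of the same phenyl: a number 0.89 log units lower from compound 2 to compound 3 (beyond the scatter). That step was modest but beyond the scatter, and it moved downward. The group entering in compound 4 is smaller and carries three hydrogen-bond acceptors where phenyl carries none, so a downward step is expected here too, and a larger one than a number 0.89 log units lower from compound 2 to compound 3 (beyond the scatter) is estimated. Compound 4 is therefore expected to come in at 6.5, somewhere between 5.5 and 7.5, an estimated change of a number 2.15 log units lower from compound 2 to compound 4 (beyond the scatter).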

Compound 4, distribution coefficient: 6.18
The estimate for compound 4 lay 0.32 log units above the measured number; the range from low to high includes it.
By their numbers in this assay, from the lowest: compound 1; then compound 4; then compound 3; then compound 2.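

Until now, only one replacement of the phenyl of compound 2 had been measured, so it was unclear how much this position could shift the number. With 1H-1,2,4-triazol-1-yl as the entering group, this assay shows a number 2.47 log units lower from compound 2 to compound 4 (beyond the scatter), a large step. The two replacement rings also differ clearly from each other, with a number 1.58 log units lower from compound 3 to compound 4 (beyond the scatter), so the outcome depends on which ring enters and not merely on the phenyl leaving; nothing available here explains that difference.

Still open, from the compounds shown here alone, is whether a ring is needed here at all, since a primary amide or a longer alkyl chain on the same aromatic carbon could give quite different numbers. Also open, going by these compounds, is whether the triazole step would keep its size with the nitrile of compound 1 in place of the chlorine.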